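The source may report more compounds than this note shows. Statements on the series, on what has been measured and on what is new or still open speak of the compounds shown alone.

The study measured two sulfonamide-containing compounds in an assay on isolated protein for inhibition of Aromatase (Homo sapiens), tested at 1 uM (a higher number here means more inhibition at the concentration tested (going by the name of the read-out), a lower number less inhibition), before turning to a third. Compound 1 `CC(C)CC1n2cncc2CN(CC2CC2)S1(=O)=O` gives 19% in this assay. Compound 2 `C[C@@H](c1ccc(Cl)cc1)N1Cc2cncn2C(CC2(C)COC2)S1(=O)=O` gives 35% in this assay, which places it highest of the two numbers; its nearest neighbour is compound 1, whose value lies lower by a gap beyond the usual scatter. Among the measured compounds shown here, the two compounds differ in more than one place, so no single structural step between them can be read from these numbers.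

Compound 3 `C[C@@H](c1ccc(Cl)cc1)N1Cc2cncn2C(C[C@@H](O)c2ccccc2)S1(=O)=O` has not yet been tested in this assay. Relative to compound 2 it carries one change: hydroxy(phenyl)methyl in place of 3-methyloxetan-3-yl on a saturated chain carbon bound to a saturated ring carbon. For the measured compounds named here, no measured pair in this set isolates such an exchange, so there is no comparable step to lean on. Compound 3 is therefore expected to give 40% in this assay, within a range from 15% to 65%. The step from compound 2 to compound 3 is estimated at a number 5 percentage points higher from compound 2 to compound 3 (within the scatter), a change that is expected to stay within the scatter of repeated measurements rather than clearly in either direction.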

Compound 3, a percentage reported as inhibition, at one concentration (the size of the read-out at that concentration, not a potency): 6%
Estimate against measurement, compound 3: 34 percentage points above, outside the stated range (below it).
By their numbers in this assay, from the lowest: compound 3; then compound 1; then compound 2.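

Among the compounds shown here, on a saturated chain carbon bound to a saturated ring carbon, hydroxy(phenyl)methyl in place of 3-methyloxetan-3-yl gives a number 29 percentage points lower from compound 2 to compound 3 (beyond the scatter) in this assay, the first comparison here in which only one part of the molecule differs, and it shows that the read-out responds to the group at this position. The exchange removes a four-membered non-aromatic ring with one hetero atom and brings in a six-membered aromatic ring of carbon only, one hydrogen-bond donor and one defined stereocentre, and this single step cannot separate these differences. No available measurement explains the lower number.

The compounds shown leave open whether the step follows the hydroxy group, the phenyl ring or the configuration of the carbon carrying them, since these always change together here. From the compounds shown here alone, a plain 2-phenylethyl chain, a 2-hydroxyethyl chain or the opposite configuration of the alcohol at the same place would pull these apart, and whether any other group at this position would go beyond compound 2 also remains open.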